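Diethylamino to hydroxymethyl-triazolyl on the amine-bearing arm

The compounds below may be only part of what the source reports. "The series", "measured", "known", "first", "only" and "open" are said of these compounds alone.

Going by the values given here, in a functional assay on MCF7 cells (Homo sapiens) for antiproliferative activity, read by MTT assay, with a stated time of 48 h (on this read-out lower numbers stand for stronger inhibition and higher numbers for weaker inhibition), compound 2 `CCN(CC)C/C1=C/C[C@](C)(CCC=C(C)C)/C=C/[C@@H](OC(=O)C=C(C)C)[C@](C)(O)/C=C/C1=O` gives 130 nM, the lowest of the two numbers so far. Compound 1 `CC(=O)O[C@]1(C)/C=C/C(=O)/C(CO)=C\C[C@](C)(CCC=C(C)C)/C=C/[C@H]1OC(=O)C=C(C)C` gives 2320 nM, a higher number that lies beyond the scatter. Compound 3 `CC(C)=CCC[C@]1(C)/C=C/[C@@H](OC(=O)C=C(C)C)[C@](C)(O)/C=C/C(=O)/C(Cn2cc(CO)nn2)=C\C1` is not yet measured; it differs from compound 2 in one place: 4-(hydroxymethyl)-1H-1,2,3-triazol-1-yl in place of diethylamino on a saturated chain carbon bound to a double-bonded ring carbon. Among the compounds with values here, no step between measured compounds covers this change, so the expectation rests on compound 2 alone. A moderate step towards a higher number is expected, a 3.1-fold higher number from compound 2 to compound 3 (0.49 log units; beyond the scatter), not firmly beyond the scatter. Compound 3 is estimated at 400 nM, within 120 nM to 1500 nM.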

Compound 3, half-maximal inhibitory concentration: 2930 nM
For compound 3 the middle estimate is 7.3-fold (0.86 log units) below the measured one; measured number above the stated range.
By their numbers in this assay, from the lowest: compound 2; then compounds 1 and 3 (each within the scatter of the next).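

In this assay the arm bearing the amine proves sensitive to the group it carries: 4-(hydroxymethyl)-1H-1,2,3-triazol-1-yl in place of diethylamino gives a 23-fold higher number from compound 2 to compound 3 (1.35 log units; beyond the scatter) as a large loss of activity. Diethylamino and this triazolyl group are therefore not interchangeable on this saturated chain carbon. No available evidence explains the loss.

On these data alone, whether the loss follows the triazole ring or its hydroxymethyl group stays open. A 4-methyl-1H-1,2,3-triazol-1-yl group or a cyclic amine such as morpholine or pyrrolidine at this place would help separate these readings.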